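Replacing the phenyl of compound 2

A few compounds are considered here, and "the series" means these few. Any claim that something is new, unique, unknown or untested is made for them only; others in the source may bear on it.

Measured so far in an ADME assay on the whole organism (serum) for protein binding, with Homo sapiens as the target, using equilibrium dialysis
Compound 1 `Cc1ccn(-c2ccc(Cn3cc(C(=O)O)c(=O)c4ccncc43)cc2)n1` gives 87.5%
Compound 2 `O=C(O)c1cn(Cc2ccc(-c3ccccc3)cc2)c2ncccc2c1=O` gives 99.2%

Of these two, compound 2 (99.2%) has the lower unbound fraction, and its gap to compound 1 lies beyond the scatter. Compound 3 `O=C(O)c1cn(Cc2ccc(-n3cccn3)cc2)c2ncccc2c1=O` keeps the core of compound 2 and exchanges one group, with 1H-pyrazol-1-yl in place of phenyl on an aromatic carbon. Among the measured compounds shown here, no measured pair isolates this change. Compound 1 (87.5%) also carries a five-membered aromatic ring with 2 hetero atoms, though its core differs from that of compound 2. This single comparison points towards more free compound, beyond the scatter but by less than the gap between the measured pair. The expected change in this assay is a 4.4-fold higher unbound fraction from compound 2 to compound 3 (0.64 log units; beyond the scatter) as estimated here. For compound 3 the estimated value is 96.5% (92% to 98.8%).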

Compound 3, plasma protein binding: 93.9%
The estimate for compound 3 lay 1.7-fold (0.24 log units) (unbound fraction) below the measured number; the range from low to high includes it.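

In this assay, among the compounds shown here, 1H-pyrazol-1-yl in place of phenyl on an aromatic carbon, para to a large group, gives a 7.6-fold higher unbound fraction from compound 2 to compound 3 (0.88 log units; beyond the scatter) on an unchanged core, the first pair to isolate this change. The earlier comparison with compound 1 mixed this ring with a different core, whereas here the group alone shifts the read-out, though compound 3 still gives 93.9%. No measurement shown accounts for the size of this step.

The compounds shown leave open whether the step follows from the two nitrogen atoms of the pyrazole or from the smaller ring itself, and whether a methyl on the pyrazole alters it. They also leave open how a morpholine or a carboxylic acid at this place would compare, and whether the same exchange would act alike on the core of compound 1.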